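Shortening the Fatty Chain of Compound 1

The source may hold more compounds than are shown below. What is called first, only, known or untested is meant among the compounds shown, and "the series" means these compounds.

In a functional assay on HeLa cells (Homo sapiens) for cytotoxicity, read by MTT assay, with a stated time of 24 h (on this read-out higher numbers stand for weaker inhibition and lower numbers for stronger inhibition), compound 1 `CCCCCCCCCCCCCCCCCC(=O)Nc1nnc(S[C@@H]2O[C@H](CO)[C@H](O)[C@H](O)[C@H]2O)s1` gives 11200 nM. For the measured compounds named here, this is the lower of the two numbers measured so far, and the gap to the other lies beyond the usual scatter: compound 2 `CCCCCCCC/C=C\CCCCCCCC(=O)Nc1nnc(S[C@@H]2O[C@H](COC(C)=O)[C@H](OC(C)=O)[C@H](OC(C)=O)[C@H]2OC(C)=O)s1` gives 54400 nM.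

Compound 3 `CCCCCCCCCC(=O)Nc1nnc(S[C@@H]2O[C@H](CO)[C@H](O)[C@H](O)[C@H]2O)s1` has not yet been measured. It keeps the core of compound 1 but carries a shorter chain: hydrogen in place of octyl on a saturated chain carbon, nine bonds along the chain from a carbonyl carbon, with hydrogen in place of octyl on a saturated chain carbon, nine bonds along the chain from a carbonyl carbon.

Going by the values given here, compound 2 differs from compound 1 in more than one place, so no measured pair isolates this change, and any forecast is uncertain. A small move toward weaker inhibition is expected, an estimated 1.8-fold higher number from compound 1 to compound 3 (0.25 log units; within the scatter). Compound 3 is expected at about 20000 nM, with an estimated range of 6000 nM to 60000 nM.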

Compound 3, half-maximal inhibitory concentration: 25900 nM
Estimate against measurement, compound 3: 1.3-fold (0.11 log units) below, within the range that was stated.
By their numbers in this assay, from the lowest: compound 1; then compound 3; then compound 2.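

For the compounds shown here, this pair is the first to isolate the fatty chain: with the core of compound 1 kept, hydrogen in place of octyl on a saturated chain carbon, nine bonds along the chain from a carbonyl carbon, gives a 2.3-fold higher number from compound 1 to compound 3 (0.36 log units; beyond the scatter). The change is modest, but it lies beyond the usual scatter, so the part of the chain that leaves does count in this assay. Its loss does not remove the effect, since compound 3 still gives 25900 nM.

As far as these compounds go, a single step cannot show how the number changes with chain length, so it remains open what a longer chain, or an amine or a carboxylic acid at this place, would do. No measurement shown here accounts for the step.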